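From oxan-2-yl to oxolan-2-yl on the shared core

The compounds below may be only part of what the source reports. "The series", "measured", "known", "first", "only" and "open" are said of these compounds alone.

Compound 1 `COc1cc(CNc2ncnc3c2ncn3C2CCCCO2)ccc1O`, compound 2 `COc1ccc(CNc2ncnc3c2ncn3C2CCCCO2)cc1OC` and compound 3 `COc1cc(OC)c(OC)cc1CNc1ncnc2c1ncn2C1CCCCO1` share one core and were tested in an ADME assay on BJ cells (Homo sapiens) for cytotoxicity, read by MTT assay, with a stated time of 72 h; on this read-out lower numbers stand for stronger inhibition and higher numbers for weaker inhibition. Compound 1 gives > 100000 nM, a limit and not a number. Compound 2 gives > 100000 nM, also a limit. Compound 3 gives > 100000 nM, again a limit. Compound 2 therefore has no exact position, and the series stands at the limit of > 100000 nM in this assay, at which 3 of the 3 values shown sit. Compound 4 `COc1ccc(CNc2ncnc3c2ncn3C2CCCO2)cc1OC` carries one change from compound 2: oxolan-2-yl in place of oxan-2-yl on an aromatic nitrogen. Going by the values given here, two measured steps bear on it only loosely: a step that the two limits leave unreadable from compound 1 to compound 2 and a step that the two limits leave unreadable from compound 2 to compound 3. Both concern groups on an aromatic ring, and neither has a readable size. The expected change is a step that the limit leaves unreadable from compound 2 to compound 4, with no step beyond the scatter foreseen. For compound 4 the estimated value is 120000 nM, within an expected range of 50000 nM to 300000 nM.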

Compound 4, half-maximal inhibitory concentration: > 100000 nM
Compound 4 ended at the assay's limit; the forecaster's own chance of this, stated with the estimate: 85%; the middle value is on the limit's open side.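

No new step can be read: compound 2 and compound 4 both stand at a limit and not at a number. The compounds shown leave open whether oxolan-2-yl and oxan-2-yl differ at all on this read-out.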